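The compounds below may be only part of what the source reports. "The series", "measured", "known", "first", "only" and "open" are said of these compounds alone.

Measured so far:
- compound 1, `COc1cc(C2CCNCC2)ccc1Nc1ncc2ccc(-c3ccccc3N(C)S(C)(=O)=O)n2n1`: > 0.666 h in an in vitro ADME assay on microsomes from liver (Mus musculus, strain CD1) for metabolic stability, using NADPH, with a stated time of 10 min, tested at 0.5 uM; on this read-out lower numbers stand for a shorter-lived compound and higher numbers for a longer-lived compound
- compound 2, `COc1cc(C2CCN(C[C@@H](C)O)CC2)ccc1Nc1ncc2ccc(-c3ccccc3OC)n2n1`: > 0.666 h in this assay
- compound 3, `COc1cc(C2CCN(CC(N)=O)CC2)ccc1Nc1ncc2c(O)cc(-c3ccccc3N(C)S(C)(=O)=O)n2n1`: < 0.0834 h in this assay

Each of these three numbers is a limit of the assay rather than a measured value. Compound 1 reaches (the limit of > 0.666 h in this assay, at which 2 of the 3 values shown sit). Compound 2 sits at that same limit. Compound 3 stands apart, at the limit of < 0.0834 h in this assay, at which 1 of the 3 values shown sits, and so is the only one of the three that is reported at the lower end of what this assay can resolve.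

Compound 4, `COc1cc(C2CCN(CC(N)=O)CC2)ccc1Nc1ncc2c(Cl)cc(-c3ccccc3N(C)S(C)(=O)=O)n2n1`, has not yet been tested in this assay. It differs from compound 3 in one place: chloro in place of hydroxy on an aromatic carbon. Within the data shown here, no measured pair shows this exact change, so its effect is not known from these data. Given that compound 3 sits at a limit, the only room to move is toward longer half-lives, and a moderate step upward from compound 3 to compound 4, an at least 3.5-fold higher number from compound 3 to compound 4 (0.55 log units; beyond the scatter), is expected. Compound 4 is therefore estimated at 0.3 h, within a range from 0.08 h to 0.7 h.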

Compound 4, half-life: > 0.666 h
Compound 4 ended at the assay's limit (the forecaster's own chance of this, stated with the estimate: 45%); at least 2.2-fold (0.34 log units) between middle value and limit.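

This is the first pair shown that differs in one place: on the five-membered aromatic ring, chloro in place of hydroxy gives an at least 7.9-fold higher number from compound 3 to compound 4 (0.90 log units; beyond the scatter) in this assay. With the rest of the molecule unchanged, this single group is enough to move the compound from one end of what the read-out can report to the other. Both values are limits of the assay rather than measured numbers, so the real step may be larger than the one printed.

The compounds shown leave open whether the short half-life is specific to hydroxy, or whether a methoxy, an amine or a fluoro at this carbon would behave like hydroxy or like chloro. On these data alone, whether the same change has the same effect in a molecule that differs elsewhere also remains open.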